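Substituent on the saturated ring carbon: compound 3 to compound 4

The compounds below may be only part of what the source reports. "The series", "measured", "known", "first", "only" and "open" are said of these compounds alone.

Measured so far:
Compound 1 `COc1cc(/C=C/C(=O)C2=C(/C=C/c3ccc(O)c(OC)c3)NC(=S)NC2c2ccccc2)ccc1O`: 16.6%
Compound 2 `COc1cc(/C=C/C(=O)C2=C(/C=C/c3ccc(O)c(OC)c3)NC(=S)NC2c2ccccc2O)ccc1O`: 34%
Compound 3 `COc1cc(/C=C/C(=O)C2=C(/C=C/c3ccc(O)c(OC)c3)NC(=S)NC2c2ccc(N(C)C)cc2)ccc1O`: 32.3%

In a functional assay, with a stated time of 20 min, tested at 2 uM (on this read-out higher numbers stand for a stronger effect at the one concentration tested and lower numbers for a weaker effect), compound 3 stands second highest of the three numbers; compound 2 lies within the scatter of it, while compound 1 lies clearly lower, as a number 15.7 percentage points higher from compound 1 to compound 3 (beyond the scatter) shows.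

Compound 4 `COc1cc(/C=C/C(=O)C2=C(/C=C/c3ccc(O)c(OC)c3)NC(=S)NC2c2c(Cl)cccc2Cl)ccc1O` has not yet been measured. It differs from compound 3 in one place: 2,6-dichlorophenyl in place of 4-(dimethylamino)phenyl on a saturated ring carbon.

Among the compounds with values here, two measured steps bear on this position. Both a number 17.4 percentage points higher from compound 1 to compound 2 (beyond the scatter) and a number 15.7 percentage points higher from compound 1 to compound 3 (beyond the scatter) were modest rises when a hydrogen on that aromatic carbon was replaced, and a number 1.7 percentage points lower from compound 2 to compound 3 (within the scatter) shows that two different groups there gave numbers within the scatter of each other. Within the data shown here, no measured step holds 2,6-dichlorophenyl, so the expectation rests on these three compounds alone.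

Compound 4 is therefore expected to stay near the level of compound 3, with a number 4.3 percentage points lower from compound 3 to compound 4 (within the scatter) estimated as a step within the scatter, and an estimated value of 28%, in the range 12% to 45%.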

Compound 4, a percentage reported as activity, at one concentration (the size of the read-out at that concentration, not a potency): 15%
For compound 4 the middle estimate is 13 percentage points above the measured one, and the stated range covers the measured number.
By their numbers in this assay, from the lowest: compounds 4 and 1 (each within the scatter of the next); then compounds 3 and 2 (each within the scatter of the next).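

In this assay the group on the saturated ring carbon turns out to matter, as 2,6-dichlorophenyl gives a number 17.3 percentage points lower from compound 3 to compound 4 (beyond the scatter) and a number 19 percentage points lower from compound 2 to compound 4 (beyond the scatter) when it replaces the other two substituted phenyl groups. Substituting the phenyl ring therefore does not by itself raise the number: 2,6-dichlorophenyl in place of phenyl gives a number 1.6 percentage points lower from compound 1 to compound 4 (within the scatter) and so leaves the read-out where plain phenyl had it, and compound 4 goes against the rise seen with compound 2 and compound 3. Nothing measured here accounts for this difference.

On these data alone, it remains open whether a phenyl carrying a single chlorine, a methoxy group or a carboxylic acid would stay with compound 4 or reach compound 2. A read-out at one concentration also tells only of a stronger or weaker effect at that concentration.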